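The compounds below may be only part of what the source reports. "The series", "measured", "known", "first", "only" and "open" are said of these compounds alone.

Values in a functional assay on DU-145 cells (Homo sapiens) for inhibition, read by trypan blue exclusion, with a stated time of 96 h; a lower number here means a stronger inhibitor of growth, a higher number a weaker inhibitor of growth:
- compound 1 `CSc1ccc(/C=C(\C(=O)c2ccc(Cl)cc2)S(=O)(=O)Cc2ccc(C)cc2)cc1`: 10000 nM
- compound 2 `CCOc1ccc(/C=C(\C(=O)c2ccc(Cl)cc2)S(=O)(=O)Cc2ccc(C)cc2)cc1OC`: 10000 nM
- compound 3 `CCOc1ccc(/C=C(/SCc2ccc(Cl)c(Cl)c2)C(=O)c2ccc(Cl)cc2)cc1OC`: 25000 nM
- compound 4 `Cc1ccc(CS(=O)(=O)/C(=C/c2c[nH]c3ccc(Br)cc23)C(=O)c2ccc(Cl)cc2)cc1`: not yet measured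

Compound 2 shares the lowest of the three numbers with compound 1. Compound 4 has 5-bromo-1H-indol-3-yl in place of 4-ethoxy-3-methoxyphenyl on a double-bonded chain carbon bound to a double-bonded chain carbon.

Within the data shown here, the closest precedent is the change at this same place, which gave no change at the digits printed from compound 1 to compound 2 (within the scatter). The other measured change, a 2.5-fold higher number from compound 2 to compound 3 (0.40 log units; beyond the scatter), lies elsewhere and bears only weakly. Among the measured compounds shown here, no compound with 5-bromo-1H-indol-3-yl has been measured, so the range is wide. In this assay, the expected change is small, with no step beyond the scatter: a 1.4-fold lower number from compound 2 to compound 4 (0.15 log units; within the scatter). For compound 4 the estimated value is 7000 nM, with an expected range of 1000 nM to 25000 nM.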

Compound 4, concentration for 50% growth inhibition: 10000 nM
Estimate against measurement, compound 4: 1.4-fold (0.15 log units) below; measured number inside the range.
By their numbers in this assay, from the lowest: compounds 1, 2 and 4 (each within the scatter of the next); then compound 3.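

In this assay, 5-bromo-1H-indol-3-yl on a double-bonded chain carbon bound to a double-bonded chain carbon brings a five-membered aromatic ring and a hydrogen-bond donor, yet the read-out stays flat (no change at the digits printed from compound 2 to compound 4 (within the scatter)) and (no change at the digits printed from compound 1 to compound 4 (within the scatter)). Three quite different groups at this place therefore cannot be told apart by this read-out. No measured evidence accounts for this flatness.

On these data alone, whether an amine or a carboxylic acid at this place would give a step beyond the scatter remains open. Also open, as far as these compounds go, is how 5-bromo-1H-indol-3-yl behaves with (3,4-dichlorobenzyl)sulfanyl in place of (4-methylbenzyl)sulfonyl.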